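The source may report more compounds than this note shows. Statements on the series, on what has been measured and on what is new or still open speak of the compounds shown alone.

Compound 1 `CC(=O)N1CCC(C(=O)N(CCCN2CCC(CNC(=O)c3cnccn3)CC2)c2ccc(C)c(Cl)c2)CC1` gives > 52400 nM in an ADME assay (Homo sapiens) for cytotoxicity (on this read-out higher numbers stand for lower toxicity in this test and lower numbers for higher toxicity in this test), which is a limit of the assay.
Compound 2 `CC(=O)N1CCC(C(=O)N(CCCN2CCC(CNc3cc(C)ccn3)CC2)c2ccc(C)c(Cl)c2)CC1` gives 17900 nM in this assay.
Compound 3 `CC(=O)N1CCC(C(=O)N(CCCN2CCC(CNc3ncccn3)CC2)c2ccc(C)c(Cl)c2)CC1` gives > 55100 nM in this assay, again a limit.

Compound 3 thus stands only at a limit, and one further value of the three is a limit as well (the limit of > 52400 nM in this assay, at which 1 of the 3 values shown sits). One measured step leads into it: an at least 3.0-fold higher number from compound 2 to compound 3 (0.48 log units; beyond the scatter). Another is not readable: a step that the two limits leave unreadable from compound 1 to compound 3. Compound 4 `CCN(Cc1ccccc1)C(=O)C1CCN(CCCN(C(=O)C2CCN(C(C)=O)CC2)c2ccc(C)c(Cl)c2)CC1` alters a different part of the shared core: benzyl(ethyl)carbamoyl in place of ((pyrimidin-2-yl)amino)methyl on a saturated ring carbon. Among the compounds with values here, none of the measured steps touches this position, so no measured step bears directly on it. Compound 4 is expected to give 40000 nM (range 15000 nM to 60000 nM) in this assay, which would mean an estimated at least 1.3-fold lower number from compound 3 to compound 4 (0.13 log units; that floor lies within the scatter).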

Compound 4, half-maximal cytotoxic concentration: 83.9 nM
The estimate for compound 4 lay 480-fold (2.68 log units) above the measured number; measured number outside the range, below it.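

In this assay the saturated ring carbon proves to be a highly sensitive position, as benzyl(ethyl)carbamoyl in place of the earlier groups gives an at least 650-fold lower number from compound 3 to compound 4 (2.81 log units; beyond the scatter) and a 210-fold lower number from compound 2 to compound 4 (2.33 log units; beyond the scatter) and an at least 620-fold lower number from compound 1 to compound 4 (2.79 log units; beyond the scatter). All three steps run the same way whichever group leaves, so compound 4 shows the highest toxicity in this test of the four compounds. Nothing measured here gives a cause for this drop. From the compounds shown here alone, it remains open which part of the entering group carries the effect. A carbamoyl bearing only an ethyl group, or a benzylamine in place of the amide, would separate these parts.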